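Chloro for cyano on the benzyl ether of compound 1

The source may report more compounds than this note shows. Statements on the series, on what has been measured and on what is new or still open speak of the compounds shown alone.

Measured compounds:
Compound 1, `Cc1nn(-c2ncnc3nc[nH]c23)c2c1C(OCc1ccccc1C#N)CC(=O)N2`: in a functional assay on HEK293 cells for agonist activity at G-protein coupled receptor 39 (Homo sapiens), read by scintillation proximity assay and inositol phosphate accumulation, with a stated time of 75 min, in the presence of a further agent that is not named here (a lower number here means that less compound is needed, a higher number that more compound is needed for the effect), compound 1 gives 8 nM.
Compound 2, `Cc1noc(C)c1COC1CC(=O)Nc2c1c(C)nn2-c1ncnc2nc[nH]c12`: in this assay compound 2 gives 5 nM.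
Compound 3, `Cc1nn(-c2ncnc3nc[nH]c23)c2c1C(NC(=O)c1ccccc1)CC(=O)N2`: in this assay compound 3 gives 3 nM.

Compound 1 has the highest number of the three. Its nearest neighbour is compound 2, a 1.6-fold lower number from compound 1 to compound 2 (0.20 log units; within the scatter); its furthest is compound 3, a 2.7-fold lower number from compound 1 to compound 3 (0.43 log units; beyond the scatter).

Compound 4, `Cc1nn(-c2ncnc3nc[nH]c23)c2c1C(OCc1ccccc1Cl)CC(=O)N2`, differs from compound 1 in one place: chloro in place of cyano on an aromatic carbon. Going by the values given here, no measured step alters a substituent on the 2-cyanophenyl ring while keeping the rest; the nearest comparison, a 1.6-fold lower number from compound 1 to compound 2 (0.20 log units; within the scatter), swaps the whole aryl group and stays within the scatter, as does a 1.7-fold lower number from compound 2 to compound 3 (0.22 log units; within the scatter). The step to compound 4 is therefore expected to be small, no change at the digits printed from compound 1 to compound 4 (within the scatter), and compound 4 is estimated at 8 nM, between 3 nM and 20 nM.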

Compound 4, half-maximal effective concentration: 2 nM
Estimate against measurement, compound 4: 4.0-fold (0.60 log units) above, outside the stated range (below it).
By their numbers in this assay, from the lowest: compounds 4, 3, 2 and 1 (each within the scatter of the next, the first and the last beyond it).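

In this assay the substituent on this aromatic carbon does matter: chloro for cyano gives a 4.0-fold lower number from compound 1 to compound 4 (0.60 log units; beyond the scatter) in the first change made on this ring alone. The 2-chlorophenyl group also separates from the dimethyl-oxazolyl group, with a 2.5-fold lower number from compound 2 to compound 4 (0.40 log units; beyond the scatter) as a step beyond the scatter, while a 1.5-fold lower number from compound 3 to compound 4 (0.18 log units; within the scatter) leaves the (2-chlorobenzyl)oxy and benzamido groups within the scatter of each other. No measurement shown here accounts for the effect of chloro.

As far as these compounds go, whether fluoro, methyl or methoxy on this aromatic carbon would match chloro remains open, as does whether chloro would have any effect on the benzoyl ring of compound 3.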